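The source may hold more compounds than are shown below. What is called first, only, known or untested is meant among the compounds shown, and "the series" means these compounds.

Notes on the series. In a functional assay on the whole organism for antagonist activity, with Mus musculus as the target (on this read-out higher numbers stand for an effect only at larger amounts of compound and lower numbers for an effect already at smaller amounts), compound 1 (`CC(C#CCN(C)C)N1CCCC1=O`) gives > 100 mg/kg, which is a limit of the assay. In this assay compound 2 (`CC(=O)N(C)CC#CCN(C)C`) gives > 10 mg/kg, which is also only a limit. Compound 3 (`COC(=O)N(C)CC#CCN(C)C`) differs from compound 2 by methoxy in place of methyl on a carbonyl carbon. Going by the values given here, no measured step covers this change. The estimated step that the limit leaves unreadable from compound 2 to compound 3 is expected to stay within the scatter, with no firm direction. For compound 3 the expected value is 15 mg/kg, with an estimated range of 5 mg/kg to 60 mg/kg.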

Compound 3, dose for half-maximal effect: > 30 mg/kg
Compound 3 was reported as a limit (the forecaster's own chance of this, stated with the estimate: 60%); middle value at least 2.0-fold (0.30 log units) away from the limit.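

Going by these compounds alone, compound 2 and compound 3 are both reported only as limits in this assay, so no step between them can be read. The compounds shown leave open whether methoxy in place of methyl on a carbonyl carbon changes the read-out at all.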